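Swapping the pyrimidine for an oxadiazole in a GIP receptor agonist

This account rests on a few compounds, and the source may have more. Where it says the series, first, only, none or still open, it means among the compounds named here.

Measured compounds:
compound 1 `CCc1cnc(N2CCC(CCCNc3ccc4c(c3)C(=O)CC4)CC2)nc1`: 167 nM
compound 2 `CC(C)(C)OC(=O)N1CCC(CCCNc2ccc3c(c2)CCCCC3=O)CC1`: "not determined" (no result reported)
compound 3 `CC(C)(C)OC(=O)N1CCC(CCCNc2ccc3c(c2)C(=O)NC3)CC1`: 892 nM

In a functional assay on CHO-K1 cells for agonist activity at Glucose-dependent insulinotropic receptor (Mus musculus), read by HTRF and cAMP accumulation, with a stated time of 30 min (a higher number here means that more compound is needed for the effect, a lower number that less compound is needed), compound 1 gives 167 nM, the lowest of the two numbers in hand. Compound 3, which carries a different capping group and a different ring fused to the aniline, gives 892 nM in this assay, a gap that lies beyond the usual scatter. Compound 2 gives "not determined" (no result reported) in this assay.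

Compound 4 `CC(C)c1noc(N2CCC(CCCNc3ccc4c(c3)C(=O)CC4)CC2)n1` keeps the core of compound 1 and changes only the capping group: 3-isopropyl-1,2,4-oxadiazol-5-yl in place of 5-ethylpyrimidin-2-yl on an amine nitrogen in a ring. Going by the values given here, both groups are small aromatic rings of the same heavy-atom count, and no measured pair shows what this exchange does. The expectation is a step within the scatter, leaning, if anywhere, toward a slightly lower number; the estimated step is a 1.3-fold lower number from compound 1 to compound 4 (0.11 log units; within the scatter). Compound 4 is therefore estimated at 130 nM in this assay, with a plausible range from 45 nM to 400 nM.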

Compound 4, half-maximal effective concentration: 158 nM
Beside the measured number, compound 4's estimate is 1.2-fold (0.08 log units) below it, and the stated range covers the measured number.
By their numbers in this assay, from the lowest: compounds 4 and 1 (each within the scatter of the next); then compound 3.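

In this assay, going by these compounds alone, the exchange of 5-ethylpyrimidin-2-yl for 3-isopropyl-1,2,4-oxadiazol-5-yl on the amine nitrogen in a ring gives a 1.1-fold lower number from compound 1 to compound 4 (0.02 log units; within the scatter), the first comparison in this set in which only one place differs. It shows that, on the core of compound 1, a five-membered aromatic ring with 3 hetero atoms can stand in for a six-membered aromatic ring with 2 hetero atoms with no change beyond the scatter. Nothing measured here accounts for this equivalence.

On these data alone, it remains open whether a group of another kind on that nitrogen, such as a simple acetyl group or a phenyl ring, would keep the number in this range. The compounds shown also leave open whether the same exchange would hold with the ring fused to the aniline in compound 3.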